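The source may hold more compounds than are shown below. What is called first, only, known or untested is meant among the compounds shown, and "the series" means these compounds.

Measured in a physicochemical assay for lipophilicity, using the shake flask method; a lower number here means a more polar compound, a higher number a more lipophilic compound:
compound 1 `C[C@H](Oc1ccc2ncc(/C=C/C(=O)NS(C)(=O)=O)c(C3CC3)c2c1)c1c(Cl)cccc1Cl` gives 2.9
compound 2 `C[C@H](Oc1ccc2ncc(/C=C/c3nn[nH]n3)c(C3CC3)c2c1)c1c(Cl)ccc(F)c1Cl` gives 3.7

Of these two measured compounds, compound 2 has the higher value, and the gap down to compound 1 lies beyond the usual scatter. The next compound to be measured, compound 3 `C[C@H](Oc1ccc2ncc(/C=C/c3nn[nH]n3)c(C3CC3)c2c1)c1c(Cl)cccc1Cl`, departs from compound 2 in one place: hydrogen in place of fluoro on an aromatic carbon (hydrogen in place of fluoro on an aromatic carbon, which turns 2,6-dichloro-3-fluorophenyl into 2,6-dichlorophenyl). Among the compounds with values here, no pair of measured compounds shows this change on its own, so the data offer no direct guide to its size. In this assay a small downward step is expected: the estimate reads a number 0.20 log units lower from compound 2 to compound 3 (within the scatter) and would stay within the scatter. The estimated value for compound 3 is 3.5 (expected range 3.1 to 3.9).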

Compound 3, distribution coefficient: 4.3
Beside the measured number, compound 3's estimate is 0.80 log units below it, outside the stated range (above it).
By their numbers in this assay, from the lowest: compound 1; then compound 2; then compound 3.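

In this assay, within the data shown here, hydrogen in place of fluoro, which turns 2,6-dichloro-3-fluorophenyl into 2,6-dichlorophenyl, gives a number 0.60 log units higher from compound 2 to compound 3 (beyond the scatter); seen on its own for the first time, this change on the aromatic carbon moves the read-out upward rather than downward. With the 2,6-dichlorophenyl group held constant, 2H-tetrazol-5-yl in place of (methylsulfonyl)carbamoyl gives a number 1.40 log units higher from compound 1 to compound 3 (beyond the scatter), so the change on the chain also moves the number beyond the scatter. Nothing available accounts for either step.

The compounds shown leave open whether a methoxy group or a nitrile on the same aromatic carbon would move the number in the same direction, and whether the fluoro-to-hydrogen step holds when (methylsulfonyl)carbamoyl replaces 2H-tetrazol-5-yl. They also leave open what a carboxylic acid on the double-bonded chain would give in this assay.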